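The compounds below may be only part of what the source reports. "The series", "measured", "known", "first", "only" and "open" are said of these compounds alone.

Of the compounds shown here, two have been measured so far. Compound 1 `CC1CCN(c2c(S(=O)(=O)c3ccc(Cl)c(Cl)c3)cnc3ccc(Cl)cc23)CC1` is tested in an assay on isolated protein for displacement of a labelled ligand from metabotropic glutamate receptor 5 (Homo sapiens), with a stated time of 60 min, tested at 1 uM (on this read-out lower numbers stand for less inhibition and higher numbers for more inhibition at the one concentration tested (going by the name of the read-out)), and gives 86%. Compound 2 `CC1CCN(c2c(S(=O)(=O)c3cccc(F)c3)cnc3ccc(F)cc23)CC1` gives 76% in this assay. Compound 2 holds the smaller of the two numbers, but the gap to compound 1 falls within the usual scatter of repeated measurements, so the two cannot be told apart on this evidence.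

Compound 3 `CC1CCN(c2c(S(=O)(=O)c3cccc(F)c3)cnc3ccc(Cl)cc23)CC1` has not been measured yet. It differs from compound 2 in one place: chloro in place of fluoro on an aromatic carbon. Among the measured compounds shown here, no pair of measured compounds differs in a single place, so no step of this kind has been observed here. The expected step from compound 2 to compound 3, a number 4 percentage points higher from compound 2 to compound 3 (within the scatter), is small, if anything slightly upward, and not beyond the scatter. This expectation rests on compound 1 carrying chloro in the same place and giving 86%. Compound 3 is therefore estimated to give 80% in this assay, with a range from 66% to 92%.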

Compound 3, a percentage reported as inhibition, at one concentration (the size of the read-out at that concentration, not a potency): 58%
Compound 3: the middle estimate sits 22 percentage points above what was measured; measured number below the stated range.
By their numbers in this assay, from the lowest: compound 3; then compounds 2 and 1 (each within the scatter of the next).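

In this assay, the position on the carbon-only aromatic ring of the core proves sensitive: chloro in place of fluoro gives a number 18 percentage points lower from compound 2 to compound 3 (beyond the scatter) and so moves the read-out beyond the scatter. The group on the sulfonyl sulfur matters as well, since 3-fluorophenyl in place of 3,4-dichlorophenyl gives a number 28 percentage points lower from compound 1 to compound 3 (beyond the scatter) while the chloro on the core stays the same. The data offer no explanation for either step.

As far as these compounds go, whether the chloro step would keep its direction with 3,4-dichlorophenyl on the sulfonyl sulfur remains open. Also open, from the compounds shown here alone, is how a bromo or methoxy group at the same core position would compare with fluoro and chloro, and how a methoxyphenyl group on the sulfur would compare with the two aryl groups seen here.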